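The source may hold more compounds than are shown below. What is called first, only, known or untested is meant among the compounds shown, and "the series" means these compounds.

Compound 1 `CCO/N=C(\CCN1CCN(c2ncccc2C)CC1)c1ccccc1`: in a functional assay on HEK293 cells with D(4) dopamine receptor (Homo sapiens) as the target, read by FLIPR (a lower number here means a smaller maximal response, a higher number a larger maximal response), compound 1 gives 49%.
Compound 2 `CO/N=C(\CCN1CCC(c2ccccn2)CC1)c1ccc(Cl)cc1`: in this assay compound 2 gives 54%.

Compound 2 and compound 1 thus give numbers that lie within the usual scatter of each other, so neither stands apart in this assay. Compound 3 `CO/N=C(/CCN1CCC(c2ccccn2)CC1)c1ccc(Cl)cc1` is not yet measured. It differs from compound 2 as follows: the two compounds have the same atoms and bonds and differ only in configuration as drawn: 1 of 1 stereo elements differ; a double bond is drawn E in compound 2 and Z in compound 3. Among the measured compounds shown here, no step between two measured compounds of this kind is available, so the expectation rests on compound 2 alone, and the change is expected to move the maximal response little, if at all, beyond the scatter. In this assay the expected step is a number 4 percentage points lower from compound 2 to compound 3 (within the scatter). For compound 3 the expected value in this assay is 50%, within the range 30% to 72%.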

Compound 3, largest response reached (reported as efficacy), in percent of the reference or control that the assay uses: 10%
Compound 3: the middle estimate sits 40 percentage points above what was measured; measured number outside the range, below it.
By their numbers in this assay, from the lowest: compound 3; then compounds 1 and 2 (each within the scatter of the next).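

Drawing the double bond Z instead of E gives a number 44 percentage points lower from compound 2 to compound 3 (beyond the scatter), so in this assay the geometry at this one double bond carries a large part of the maximal response. Compounds 1 and 2 differ in more than one place and could show nothing of this. The step can be assigned to the double bond alone because nothing else changes: the fact that compounds 2 and 3 differ only in the configuration as drawn.

As far as these compounds go, what the Z geometry does on the core of compound 1 stays open. So does whether the step holds with a longer chain or an amide in the shared core.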